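A Side-Chain Swap on the Stronger of Two Compounds

This account rests on a few compounds, and the source may have more. Where it says the series, first, only, none or still open, it means among the compounds named here.

Within the data shown here, compound 2 (`CC[C@H](N)C(=O)N1CCc2c(C)c3c(n2-c2ccc(C(N)=O)c(c2)N[C@@H](C)[C@H](C)C1)CC(C)(C)CC3=O`) gives 45 nM in a functional assay on U-87MG ATCC cells (Homo sapiens) for antiproliferative activity (on this read-out lower numbers stand for stronger inhibition and higher numbers for weaker inhibition), and holds the lower of the two numbers measured so far. Compound 1 (`Cc1c2c(n3c1CCCN(C(=O)CN)[C@@H](C)[C@H](C)Nc1cc-3ccc1C(N)=O)CC(C)(C)CC2=O`) gives 481 nM in the same test, and that gap lies beyond the usual scatter of repeated measurements. These two compounds differ in more than one place, so their gap cannot be pinned on any single group.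

Compound 3 (`Cc1c2c(n3c1CCN(C(=O)[C@H](C)O)C[C@@H](C)[C@H](C)Nc1cc-3ccc1C(N)=O)CC(C)(C)CC2=O`) has not been measured yet. It carries 1-hydroxyethyl in place of 1-aminopropyl on a carbonyl carbon and otherwise matches compound 2. Among the measured compounds shown here, no measured pair shows this swap, which leaves compound 2 at 45 nM as the only direct starting point and makes the forecast a judgement. A modest weakening is expected, with the estimate being a 2.7-fold higher number from compound 2 to compound 3 (0.43 log units; beyond the scatter) in this assay and the uncertainty wide enough to include little change. Compound 3 is estimated at 120 nM with an expected range of 30 nM to 500 nM for now.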

Compound 3, half-maximal inhibitory concentration: 88 nM
Compound 3: middle estimate off by 1.4-fold (0.13 log units), on the high side; the measured number falls inside the stated range.
By their numbers in this assay, from the lowest: compounds 2 and 3 (each within the scatter of the next); then compound 1.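

Among these compounds, this is the first comparison here that changes only one place. In this assay, putting 1-hydroxyethyl in place of 1-aminopropyl on a carbonyl carbon, whose other neighbour is an amide-type nitrogen in a ring, gives a 2.0-fold higher number from compound 2 to compound 3 (0.29 log units; within the scatter). For this one pair, then, the nitrogen of the 1-aminopropyl group is not needed to keep the number within the scatter of the parent, so this position accepts a side chain that ends in a different heteroatom. Nothing measured here explains why the two side chains read so alike.

The swap alters two things at once, exchanging the nitrogen for an oxygen and shortening the chain from propyl to ethyl, and the compounds shown cannot separate these two changes or show whether they offset each other. A 1-aminoethyl or 1-hydroxypropyl group on the same carbonyl would pull them apart, while a carboxylic acid there would show whether this tolerance extends to a quite different kind of group.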